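This account rests on a few compounds, and the source may have more. Where it says the series, first, only, none or still open, it means among the compounds named here.

In a functional assay on the whole organism with Mus musculus as the target (a lower number here means that less compound is needed, a higher number that more compound is needed for the effect), compound 1 (`CCn1c(=O)[nH]c2c(ncn2C2O[C@H](CO)[C@@H](O)[C@H]2O)c1=N`) gives > 100 mg/kg as a limit and not a number. Compound 2 (`CCCCn1c(=O)[nH]c2c(ncn2C2O[C@H](CO)[C@@H](O)[C@H]2O)c1=N`) gives > 100 mg/kg as a limit too, so its standing is known only as a limit. Among the measured compounds shown here, the one measured step (a step that the two limits leave unreadable from compound 1 to compound 2) has no readable size. For the measured compounds named here, compound 3 (`N=c1c2ncn(C3O[C@H](CO)[C@@H](O)[C@H]3O)c2[nH]c(=O)n1-c1ccccc1`) carries phenyl in place of butyl on an aromatic nitrogen and no measured step covers that exchange. The expectation rests only on the limit of > 100 mg/kg in this assay, at which 2 of the 2 values shown sit, with compound 1 and compound 2 both sitting there. In this assay no clear step in either direction is therefore expected, and a further limit is the likelier report. The estimated step (a step that the limit leaves unreadable from compound 2 to compound 3) is nominal, with compound 2 known only as a limit. For compound 3 the estimate is 150 mg/kg with an expected range from 40 mg/kg to 400 mg/kg as its span.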

Compound 3, dose for half-maximal effect: > 100 mg/kg
Compound 3: only a limit was reported; the forecaster's own chance of this, stated with the estimate: 80%; the middle value is on the limit's open side.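

In this assay, among the compounds shown here, compound 3 gives > 100 mg/kg, again a limit and not a number, so no step from compound 1 or compound 2 to compound 3 can be read. The compounds shown leave open whether ethyl, butyl or phenyl on the aromatic nitrogen makes any difference in this assay.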